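This account rests on a few compounds, and the source may have more. Where it says the series, first, only, none or still open, it means among the compounds named here.

Three compounds share one core and differ only in the aryl ring attached to an aromatic carbon. Compound 1 `COc1ccc(-c2c(S(=O)(=O)c3cc(F)cc(F)c3)cnc3cc(F)ccc23)cc1` gives 1.51 mL/min in an ADME assay on microsomes from liver (Homo sapiens) for metabolic stability, tested at 2.5 uM (on this read-out lower numbers stand for slow clearance and higher numbers for fast clearance), compound 2 `COc1cccc(-c2c(S(=O)(=O)c3cc(F)cc(F)c3)cnc3cc(F)ccc23)c1` gives 1.81 mL/min, and compound 3 `O=S(=O)(c1cc(F)cc(F)c1)c1cnc2cc(F)ccc2c1-c1cccc(Cl)c1` gives 0.22 mL/min, the lowest of the three. The steps of a 6.9-fold lower number from compound 1 to compound 3 (0.84 log units; beyond the scatter) and an 8.2-fold lower number from compound 2 to compound 3 (0.92 log units; beyond the scatter) both concern that ring. Compound 4 `Cc1ccc(S(=O)(=O)c2cnc3cc(F)ccc3c2-c2cccc(Cl)c2)cc1C` instead changes the group on the sulfonyl sulfur: 3,4-dimethylphenyl in place of 3,5-difluorophenyl on a sulfonyl sulfur. Within the data shown here, no measured step touches this part of the molecule, so nothing shows how this assay answers to such a change; the expectation rests on compound 3 alone and carries a wide range. Compound 4 is therefore expected to give 0.4 mL/min, somewhere between 0.15 mL/min and 1.2 mL/min. The expected step is then a 1.8-fold higher number from compound 3 to compound 4 (0.26 log units; within the scatter).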

Compound 4, intrinsic clearance in a liver preparation (reported as CLH), per the amount of preparation that the assay uses: 4.01 mL/min
The estimate for compound 4 lay 10-fold (1.00 log units) below the measured number; the whole stated range lies below it.
By their numbers in this assay, from the lowest: compound 3; then compounds 1 and 2 (each within the scatter of the next); then compound 4.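

In this assay, the group on the sulfonyl sulfur proves able to move the number: 3,4-dimethylphenyl in place of 3,5-difluorophenyl gives an 18-fold higher number from compound 3 to compound 4 (1.26 log units; beyond the scatter). Both groups are six-membered aromatic rings of carbon only with no hydrogen-bond donors or acceptors, so these shared features do not separate them. Nothing available explains the step.

Going by these compounds, it remains open how a single methyl, a methoxy or an amine on this ring would read. Also open, on these data alone, is whether the same swap gives a similar step with the 4-methoxyphenyl of compound 1.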